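This account rests on a few compounds, and the source may have more. Where it says the series, first, only, none or still open, it means among the compounds named here.

Measured in an ADME assay on Caco-2 cells (Homo sapiens) for permeability, in the apical to basolateral direction, at pH 7.4; a lower number here means that the compound crosses the layer more slowly, a higher number that the compound crosses the layer faster:

- compound 1 `O=C(N[C@H]1CN(S(=O)(=O)c2ccccc2)C[C@@H]1C(=O)N[C@H]1CCCNC1)c1cc(-c2ccccc2)on1`: 0.12 10^-6 cm/s
- compound 2 `O=C(N[C@H]1CN(S(=O)(=O)c2ccccc2)C[C@@H]1C(=O)N[C@H]1CCCNC1)c1cc(-c2ccccc2Cl)on1`: 0.31 10^-6 cm/s
- compound 3 `O=C(N[C@H]1CN(S(=O)(=O)c2ccccc2)C[C@@H]1C(=O)N1C[C@H]2CCNC[C@H]21)c1cc(-c2ccccc2Cl)on1`: 0.53 10^-6 cm/s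

Among the measured compounds shown here, two measured steps touch compound 2. The first is a 2.6-fold higher number from compound 1 to compound 2 (0.41 log units; beyond the scatter), and the second is a 1.7-fold higher number from compound 2 to compound 3 (0.23 log units; within the scatter). Compound 2 therefore stands clearly apart from compound 1, but it cannot be told apart from compound 3.

The next compound to be measured is compound 4 `CN(C(=O)c1cc(-c2ccccc2Cl)on1)[C@H]1CN(S(=O)(=O)c2ccccc2)C[C@@H]1C(=O)N[C@H]1CCCNC1`, which differs from compound 2 by a single change: methyl in place of hydrogen on an amide-type nitrogen. In words, this is methyl in place of hydrogen on an amide-type nitrogen.

Neither measured step alters that nitrogen, so no measurement here shows directly what this change does. The two steps serve only as a rough yardstick of how far one small change has moved the number in this series. One swapped chloro for hydrogen on an aromatic carbon, and the other swapped the group on a carbonyl carbon. Both moved the number up, but at other places in the molecule, so the direction remains a weak guess. A small rise is expected, and the estimated size is a 1.5-fold higher number from compound 2 to compound 4 (0.16 log units; within the scatter). For compound 4 the expected value is 0.45 10^-6 cm/s, with an estimated range from 0.18 10^-6 cm/s to 1.1 10^-6 cm/s.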

Compound 4, apparent permeability: 0.06 10^-6 cm/s
Compound 4: middle estimate off by 7.5-fold (0.88 log units), on the high side; the whole stated range lies above it.
By their numbers in this assay, from the lowest: compounds 4 and 1 (each within the scatter of the next); then compounds 2 and 3 (each within the scatter of the next).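

Putting methyl in place of the amide hydrogen on this amide-type nitrogen, whose other neighbours are a carbonyl carbon and a saturated ring carbon, gives a 5.2-fold lower number from compound 2 to compound 4 (0.71 log units; beyond the scatter) in this assay and shows that the number responds to a change at this nitrogen, even one that adds a single carbon. Among the compounds shown here, the only earlier step beyond the scatter, chloro in place of hydrogen on an aromatic carbon, gives a 2.6-fold higher number from compound 1 to compound 2 (0.41 log units; beyond the scatter) and runs in the opposite direction, so an upward step at that other place says nothing reliable about this nitrogen. No accompanying measurement explains the change, and the reason for the lower number remains unknown.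

Methyl is the only group on this nitrogen among the compounds shown, so it remains open whether a longer chain such as ethyl, or a small ring such as cyclopropyl, would give a similar number in this assay or a different one. On these data alone, it also remains open whether methyl at this nitrogen would give a step of similar size in compound 3, which carries a different group on the carbonyl carbon.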